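The source may hold more compounds than are shown below. What is called first, only, known or untested is meant among the compounds shown, and "the series" means these compounds.

Among the measured compounds shown here, compound 2 `COc1cc(Cl)cc(-c2nn(-c3cccc(NC(=O)Nc4cccc(C(F)(F)F)c4)c3)cc2-c2ccncc2)c1` gives 98% in a functional assay on HCC 2998 cells (Homo sapiens) for inhibition, read by sulforhodamine B assay, with a stated time of 48 h, tested at 1 uM (a higher number here means a weaker effect of the compound at the concentration tested, a lower number a stronger effect), and stands highest of the two numbers measured so far, with compound 1 `COc1cc(Cl)cc(-c2nn(-c3cccc(NC(=O)Nc4ccc(Cl)c(C(F)(F)F)c4)c3)cc2-c2ccncc2)c1` nearest at 97%; the step of a number 1 percentage points higher from compound 1 to compound 2 (within the scatter) lies within the scatter, so the two values are read as the same. Compound 3 `COc1cc(Cl)cc(-c2nn(-c3cccc(NC(=O)c4cccc(C(F)(F)F)c4)c3)cc2-c2ccncc2)c1` is the next member: 3-(trifluoromethyl)phenyl in place of (3-(trifluoromethyl)phenyl)amino on a carbonyl carbon. For the measured compounds named here, the only measured step concerns a different position, hydrogen in place of chloro on an aromatic carbon, and no step touches the carbonyl carbon, so nothing measured bears directly on the change to compound 3. Going by the values given here, with both measured values near the top of the scale and no contrary step, compound 3 is expected to come out close to them, an expected step of a number 3 percentage points lower from compound 2 to compound 3 (within the scatter) that stays within the scatter. The estimate for compound 3 is 95%, with a range from 82% to 104%.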

Compound 3, a percentage reported as activity, at one concentration (the size of the read-out at that concentration, not a potency): 103%
Estimate against measurement, compound 3: 8 percentage points below, and the stated range covers the measured number.
By their numbers in this assay, from the lowest: compounds 1, 2 and 3 (each within the scatter of the next).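

In this assay, the change on the carbonyl carbon removes the amino nitrogen with its hydrogen-bond donor and gives a number 5 percentage points higher from compound 2 to compound 3 (within the scatter), so the two compounds are read as the same. The wider change, which also removes the chloro, gives a number 6 percentage points higher from compound 1 to compound 3 (within the scatter) and likewise cannot be told apart from no change. This position therefore tolerates the loss of that nitrogen without a readable shift, with all three compounds remaining near the weak-effect end of the scale. No available measurement offers an explanation for this result.

On these data alone, it remains open whether any group on this carbonyl carbon can move the read-out out of this narrow band. An amine, a carboxylic acid or a longer alkyl chain in place of 3-(trifluoromethyl)phenyl would test this.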